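The compounds below may be only part of what the source reports. "The series", "measured", "known", "first", "only" and "open" are said of these compounds alone.

Measured so far in a functional assay on HL-60 cells (Homo sapiens) for inhibition, read by MTT assay, with a stated time of 48 h, tested at 10 uM; a higher number here means more inhibition of growth at the concentration tested, a lower number less inhibition of growth:

- Compound 1 `Cc1cc(=O)c2c(O)c(CN3CCN(C(=O)OC(C)(C)C)CC3)c(O)c([C@H]3CCN(C)C[C@H]3O)c2o1`: 13%
- Compound 2 `Cc1cc(=O)c2c(O)c(CN(C)CC(=O)O)c(O)c([C@H]3CCN(C)C[C@H]3O)c2o1`: 23%

These two values lie within the usual scatter of repeated measurements, so compound 2 stands level with compound 1 and the numbers do not separate them. Both compounds share a core and differ in the group carried on a saturated chain carbon bound to an aromatic carbon.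

The next compound, compound 3 `Cc1cc(=O)c2c(O)c(CN3CCCCC3)c(O)c([C@H]3CCN(C)C[C@H]3O)c2o1`, changes that same place. Going from compound 2 to compound 3, piperidin-1-yl takes the place of (carboxymethyl)(methyl)amino: piperidin-1-yl in place of (carboxymethyl)(methyl)amino on a saturated chain carbon bound to an aromatic carbon.

Among the compounds with values here, no measured pair shows this exact change, and no measured compound carries piperidin-1-yl, so the expectation rests on thin evidence. Compound 1, with a different group in this place, gives 13%, and compound 2 gives 23%. That gap stays within the scatter, so a large shift is not expected here. In this assay, the expected change is small and slightly upward, a number 2 percentage points higher from compound 2 to compound 3 (within the scatter), with no step beyond the scatter anticipated. For compound 3 the estimated value is 25%, with an expected range from 8% to 50%.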

Compound 3, percent growth inhibition at one concentration: 32%
For compound 3 the middle estimate is 7 percentage points below the measured one; the measured number falls inside the stated range.
By their numbers in this assay, from the lowest: compounds 1, 2 and 3 (each within the scatter of the next, the first and the last beyond it).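

In this assay, piperidin-1-yl in place of (carboxymethyl)(methyl)amino gives a number 9 percentage points higher from compound 2 to compound 3 (within the scatter), so at this position the open chain carrying a carboxylic acid and the six-membered ring cannot be told apart. Within the data shown here, the new result does show that the group at this place can matter: compound 1 gives 13% and compound 3 gives 32%, the first pair whose values lie beyond the scatter of each other. No measurement is at hand that would explain these numbers, so they record an outcome and not its cause.

The compounds shown leave open whether the ring itself counts or only the loss of the carboxylic acid, a question that an open-chain diethylamino group or a smaller pyrrolidin-1-yl ring at this place could help to settle, while a morpholin-4-yl ring would test an oxygen within the ring. Going by these compounds, each value also comes from a single concentration, so how these compounds compare across a range of concentrations remains unknown.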